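Cytotoxicity of Two Amides and a Planned Nitrile Analogue

The source may hold more compounds than are shown below. What is called first, only, known or untested is meant among the compounds shown, and "the series" means these compounds.

Measured so far:
compound 1, `CCC(=O)Nc1ncc(-c2ccc(OC)cc2)n1C` – > 100000 nM
compound 2, `O=C(Nc1ncc(-c2ccccc2)o1)c1ccc(F)cc1` – 17000 nM

Both compounds were tested in a toxicity assay on THP-1 cells (Homo sapiens) for inhibition; on this read-out higher numbers stand for lower toxicity in this test and lower numbers for higher toxicity in this test. For compound 1 the result is a limit of the assay rather than a number: compound 1 shows > 100000 nM, meaning no half-maximal cytotoxic concentration could be reached within the tested range, as described by the limit of > 100000 nM in this assay, at which 1 of the 2 values shown sits. Compound 2, an amide built on a different core, gives 17000 nM in this assay. For the measured compounds named here, no step between compound 1 and compound 2 is defined here, since they differ in more than one place; their two values simply show one compound at the limit and the other with a measurable concentration.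

The compound still to be measured is compound 3, `COc1ccc(-c2cnc(NC(=O)c3ccc(C#N)cc3)n2C)cc1`. It differs from compound 1 in a single place: 4-cyanophenyl in place of ethyl on a carbonyl carbon.

Since compound 1 sits at the limit, any step from compound 1 to compound 3 can only go towards a measurable value or stay at the limit. Compound 3 is expected to be somewhat more toxic, with an estimated step of an at least 2.5-fold lower number from compound 1 to compound 3 (0.39 log units; beyond the scatter). For compound 3 the estimate is 40000 nM, with a range from 10000 nM to 150000 nM.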

Compound 3, half-maximal cytotoxic concentration: > 100000 nM
Compound 3: no number, only a limit (the forecaster's own chance of this, stated with the estimate: 40%); middle value at least 2.5-fold (0.39 log units) away from the limit.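

In this assay compound 3 gives > 100000 nM as a limit of the assay and not a number. For the compounds shown here, no step from compound 1 to compound 3 can be read, because both compounds sit at this limit: the limit of > 100000 nM in this assay, at which 2 of the 3 values shown sit.

The compounds shown leave open whether 4-cyanophenyl in place of ethyl on a carbonyl carbon changes the result in this assay at all.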